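The compounds below may be only part of what the source reports. "The series", "measured", "known", "first", "only" and "open" are said of these compounds alone.

Measured in an ADME assay on C8166 cells (Homo sapiens) for cytotoxicity, read by MTT assay; on this read-out lower numbers stand for higher toxicity in this test and higher numbers for lower toxicity in this test:
- compound 1 `O=C(O)c1cn(-c2ccc(Br)cc2)c2ccc(Cc3cccc(Cl)c3F)c(O)c2c1=O`: 85000 nM
- compound 2 `O=C(O)c1cn(Cc2ccccc2)c2ccc(Cc3ccccc3F)c(O)c2c1=O`: 156000 nM
- compound 3 `O=C(O)c1cn(Cc2ccccc2)c2ccc(Cc3cccc(Cl)c3F)c(O)c2c1=O`: 20300 nM

Compound 2 and compound 1 lie within the usual scatter of each other, and compound 3 stands clear of both. Compound 4 `O=C(O)c1cn(Cc2ccccc2F)c2ccc(Cc3ccccc3F)c(O)c2c1=O` differs from compound 2 by fluoro in place of hydrogen on an aromatic carbon, which turns benzyl into 2-fluorobenzyl.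

Among the measured compounds shown here, no fluoro step has been measured. For the measured compounds named here, the nearest precedent is the chloro step, a 7.7-fold lower number from compound 2 to compound 3 (0.89 log units; beyond the scatter), though it falls elsewhere on the molecule. The other step, a 4.2-fold lower number from compound 1 to compound 3 (0.62 log units; beyond the scatter), shows that the number in this assay can shift with the group on the aromatic nitrogen, the group that changes here. Both steps are modest and both lead to lower numbers, so a smaller move in that direction is expected, with no change beyond the scatter also possible. The expected step is a 1.7-fold lower number from compound 2 to compound 4 (0.24 log units; within the scatter). For compound 4 the estimated value is 90000 nM, with an expected range from 30000 nM to 200000 nM.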

Compound 4, half-maximal cytotoxic concentration: 67100 nM
The estimate for compound 4 lay 1.3-fold (0.13 log units) above the measured number; the range from low to high includes it.
By their numbers in this assay, from the lowest: compound 3; then compounds 4, 1 and 2 (each within the scatter of the next, the first and the last beyond it).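

In this assay, the one added fluoro on the benzyl group gives a 2.3-fold lower number from compound 2 to compound 4 (0.37 log units; beyond the scatter), so a single hydrogen replaced on this group on the aromatic nitrogen is enough to move the number, modestly but beyond the scatter, towards higher toxicity in this test. The earlier step at this nitrogen exchanged a whole group, 4-bromophenyl for benzyl, whereas this one shows that a substituent on the benzyl ring itself matters, and it is the only fluoro step shown. The data give no explanation for the shift.

The compounds leave open whether a chloro or a methoxy group at the same place on the benzyl ring would move the number in the same direction. They also leave open whether this fluoro step and the chloro step elsewhere on the molecule would add up when combined.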